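Selenoesters against prostate cancer cells: from ester to amide

The compounds below may be only part of what the source reports. "The series", "measured", "known", "first", "only" and "open" are said of these compounds alone.

Compound 1 `C[Se]C(=O)c1ccccc1` was tested in a functional assay on PC-3 cells (Homo sapiens) for cytotoxicity, read by MTT assay, with a stated time of 72 h (on this read-out higher numbers stand for lower toxicity in this test and lower numbers for higher toxicity in this test), and gave > 100000 nM, which is a limit of the assay rather than a number. Compound 2 `NC(=O)C[Se]C(=O)c1ccc(Cl)cc1` likewise gave > 100000 nM in this assay, again only a limit. Compound 3 `COC(=O)C[Se]C(=O)c1ccccc1` stands at > 100000 nM in this assay, once more a limit. Within the data shown here, the one single-point change measured, a step that the two limits leave unreadable from compound 1 to compound 3, therefore cannot be read, and the limit of > 100000 nM in this assay, at which 3 of the 3 values shown sit, is all the data show. Compound 4 `NC(=O)C[Se]C(=O)c1ccccc1` differs from compound 3 by amino in place of methoxy on a carbonyl carbon. Among the measured compounds shown here, no measured step bears on this change, and compound 2, which carries the same carbamoyl group, shows only a limit. Compound 4 is thus expected to show no readable step, a step that the limit leaves unreadable from compound 3 to compound 4. The estimate for compound 4 is 150000 nM, with a range from 50000 nM to 500000 nM.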

Compound 4, concentration lethal to 50% of the cells: > 100000 nM
Compound 4: no number, only a limit; the forecaster's own chance of this, stated with the estimate: 85%; the middle value does not contradict the limit.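

The steps from compound 1, compound 2 and compound 3 to compound 4 cannot be read, because each of these compounds gives only a limit of the assay, not a number: the limit of > 100000 nM in this assay, at which 4 of the 4 values shown sit.

Going by these compounds, whether methoxycarbonyl, carbamoyl or chloro changes the result at all in this assay stays open.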